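Isopropyl for benzyl on the purine-type core: an unmeasured step

A few compounds are considered here, and "the series" means these few. Any claim that something is new, unique, unknown or untested is made for them only; others in the source may bear on it.

Measured compounds:
compound 1, `Nc1ccccc1NC(=O)c1ccc(CNc2nc(Cl)nc3c2ncn3Cc2ccccc2)cc1`: 11.5%
compound 2, `CC(C)n1cnc2c(Nc3cccc(Cl)c3)nc(NCOCc3ccc(/C=C/C(=O)Nc4ccccc4N)cc3)nc21`: 27.9%

Compound 1 stands lowest of the two numbers measured in a functional assay on HCT-116 cells (Homo sapiens) for antiproliferative activity, read by CCK-8 assay, with a stated time of 72 h, tested at 8 uM; a higher number here means a stronger effect of the compound at the concentration tested, a lower number a weaker effect. Among the measured compounds shown here, the nearest number is that of compound 2, which in this assay gives 27.9%, a gap beyond the usual scatter, although the two structures differ in many places at once and no single step connects them. Compound 3, `CC(C)n1cnc2c(NCc3ccc(C(=O)Nc4ccccc4N)cc3)nc(Cl)nc21`, has not yet been measured. It differs from compound 1 in one place: isopropyl in place of benzyl on an aromatic nitrogen. Compound 2 also carries isopropyl on its aromatic nitrogen, but its several other differences from compound 1 leave the share of that one change unknown. For the measured compounds named here, no measured pair shows what this exchange alone does. The step from compound 1 to compound 3 is therefore expected to be small, a number 4.5 percentage points higher from compound 1 to compound 3 (within the scatter), most likely within the scatter, with the direction uncertain. Compound 3 is estimated to give 16% in this assay, within a range from 3% to 34%.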

Compound 3, a percentage reported as inhibition, at one concentration (the size of the read-out at that concentration, not a potency): 76%
For compound 3 the middle estimate is 60 percentage points below the measured one, outside the stated range (above it).
By their numbers in this assay, from the lowest: compound 1; then compound 2; then compound 3.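

Within this assay, isopropyl in place of benzyl on the aromatic nitrogen gives a number 64.5 percentage points higher from compound 1 to compound 3 (beyond the scatter) and so provides the first reading of a single change in this set. With the rest of the structure held constant, the group on this nitrogen alone separates a weak read-out from a strong one at the concentration tested, so the position is far from indifferent to what it carries. Nothing measured here bears on the cause of this rise.

This one exchange removes the aromatic ring and lowers the heavy-atom count together, so it cannot show which of the two goes with the higher number. Methyl, ethyl or cyclopentyl on the same nitrogen would begin to separate them, and whether the step holds on other structures remains open.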